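Pyrazole swap at the cytotoxicity limit

The source may report more compounds than this note shows. Statements on the series, on what has been measured and on what is new or still open speak of the compounds shown alone.

Compound 2 (`OC[C@H]1O[C@@H](n2cnc3c(COc4ccccn4)ncnc32)[C@H](O)[C@@H]1O`) gives > 250000 nM in a functional assay on Huh-7 cells (Homo sapiens) for cytotoxicity, read by MTT assay, with a stated time of 3 days (a lower number here means that less compound is tolerated, a higher number that more compound is tolerated), as a limit, not a number. Compound 1 (`OC[C@H]1O[C@@H](n2cnc3c(Cn4ccc5ccccc54)ncnc32)[C@H](O)[C@@H]1O`) gives > 250000 nM as a limit too. Neither compound has a number to rank it (the limit of > 250000 nM in this assay, at which 2 of the 2 values shown sit). Compound 3 (`OC[C@H]1O[C@@H](n2cnc3c(Cn4cccn4)ncnc32)[C@H](O)[C@@H]1O`) has 1H-pyrazol-1-yl in place of (pyridin-2-yl)oxy on a saturated chain carbon bound to an aromatic carbon. Among the compounds with values here, the single measured change (a step that the two limits leave unreadable from compound 1 to compound 2) gives no size to carry forward, so no step beyond the scatter is expected in this assay and another limit is likely. The estimated change is small (a number no higher from compound 2 to compound 3 (the limit leaves the size open)). Compound 3 is estimated at 250000 nM with an expected range of 120000 nM to 500000 nM in this assay.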

Compound 3, half-maximal cytotoxic concentration: > 250000 nM
Compound 3 ended at the assay's limit; the forecaster's own chance of this, stated with the estimate: 85%; the middle value lies on the limit itself.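

In this assay, within the data shown here, compound 3 gives > 250000 nM as a limit, not a number, so no step among compound 1, compound 2 and compound 3 can be read. As far as these compounds go, whether these three groups on the saturated chain carbon differ in cytotoxicity at all remains open.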